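The compounds below may be only part of what the source reports. "The series", "measured", "known", "first", "only" and "open" are said of these compounds alone.

Compound 1 `CC1CCN(c2c(S(=O)(=O)c3ccc(F)c(F)c3)cnc3c(F)cccc23)CC1` gives 93% in an assay on isolated protein for displacement of a labelled ligand from metabotropic glutamate receptor 5 (Homo sapiens), with a stated time of 60 min, tested at 1 uM; on this read-out lower numbers stand for less inhibition and higher numbers for more inhibition at the one concentration tested (going by the name of the read-out). Compound 2 `COc1ccc2ncc(S(=O)(=O)c3ccc(Cl)c(Cl)c3)c(N3CCC(C)CC3)c2c1` gives 87% in this assay, so on the two numbers at hand compound 1 stands level with compound 2, the gap lying within the usual scatter. Compound 3 `Cc1ccc(S(=O)(=O)c2cnc3c(F)cccc3c2N2CCC(C)CC2)cc1F` remains to be measured; it differs from compound 1 by methyl in place of fluoro on an aromatic carbon. For the measured compounds named here, with both measured compounds sitting near the top of the scale and no comparable step on record, the change from compound 1 to compound 3 is estimated at a number 5 percentage points lower from compound 1 to compound 3 (within the scatter), a shift not beyond the scatter. Compound 3 is therefore expected to give about 88%, between 72% and 97%.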

Compound 3, a percentage reported as inhibition, at one concentration (the size of the read-out at that concentration, not a potency): 93%
Beside the measured number, compound 3's estimate is 5 percentage points below it; the range from low to high includes it.
By their numbers in this assay, from the lowest: compounds 2, 1 and 3 (each within the scatter of the next).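

Putting methyl in place of fluoro on the aromatic carbon para to a large group gives no change at the digits printed from compound 1 to compound 3 (within the scatter) in this assay and turns 3,4-difluorophenyl into 3-fluoro-4-methylphenyl. For the compounds shown here, this is the first direct comparison at this position, and it shows that inhibition at the one concentration tested stays high with either group there. Nothing on hand explains why the two groups read alike. Going by these compounds, whether an amine, a carboxylic acid or a longer chain at this position would give a higher, lower or level number in this assay remains open. Also open, on these data alone, is whether fluoro and methyl would still match in a full potency measurement.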